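Removing (2-carboxyethyl)carbonyl from compound 3

This account rests on a few compounds, and the source may have more. Where it says the series, first, only, none or still open, it means among the compounds named here.

In a functional assay on HepG2 cells (Homo sapiens) for cytotoxicity, read by MTT assay, with a stated time of 72 h (a higher number here means a weaker inhibitor, a lower number a stronger inhibitor), compound 3 `Cc1c(C)c2c(c(C)c1OC(=O)CCC(=O)O)CCC(C)(C(=O)NCC1CC(C)(C)N([O])C1(C)C)O2` gives only a limit, > 300000 nM. Compound 1 `Cc1c(C)c2c(c(C)c1OC(=O)CCC(=O)O)CCC(C)(C(=O)NC1CC(C)(C)N([O])C(C)(C)C1)O2` also gives only a limit, > 300000 nM. Compound 2 `CC1(C)CC(CNC(=O)CCC(=O)O)C(C)(C)N1[O]` likewise gives only a limit, > 300000 nM. Every measured value thus stands at the limit of > 300000 nM in this assay, at which 3 of the 3 values shown sit. Compound 4 `Cc1c(C)c2c(c(C)c1O)CCC(C)(C(=O)NCC1CC(C)(C)N([O])C1(C)C)O2` differs from compound 3 by hydrogen in place of (2-carboxyethyl)carbonyl on an oxygen on an aromatic ring. All three measured compounds carry (2-carboxyethyl)carbonyl, so none shows what its removal does. For the measured compounds named here, the one measured step, a step that the two limits leave unreadable from compound 1 to compound 3, offers no size to carry over. No change beyond the scatter is therefore expected in this assay, and the estimated a number no higher from compound 3 to compound 4 (the limit leaves the size open) has no firm direction. Compound 4 is expected at 300000 nM, with an estimated range from 100000 nM to 600000 nM.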

Compound 4, half-maximal inhibitory concentration: > 300000 nM
Compound 4 gave a limit, no number; the forecaster's own chance of this, stated with the estimate: 70%; the middle value lies on the limit itself.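

No step can be read between compound 3 and compound 4: each gives only a limit in this assay. The compounds shown leave open what number any of them would give, and whether hydrogen in place of (2-carboxyethyl)carbonyl changes it at all.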